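Fluorine on the Benzyl Arm of a Pyrimidine Amide

A few compounds are considered here, and "the series" means these few. Any claim that something is new, unique, unknown or untested is made for them only; others in the source may bear on it.

The study measures a functional assay on the whole organism (artery, strain albino) with Rattus norvegicus as the target, with a stated time of 30 min, at a dose of 10 mg/kg by the oral route (on this read-out lower numbers stand for less inhibition and higher numbers for more inhibition at the one dose given (going by the name of the read-out)), for a small set of closely related compounds. Compound 1 `CC1=C(C(=O)Nc2ccc(F)cc2)C(c2ccc([N+](=O)[O-])cc2)N=C(SCc2ccc(F)cc2)N1` gives 5.7%. Compound 2 `CC1=C(C(=O)Nc2ccc([N+](=O)[O-])cc2)C(c2ccc(Br)cc2)N=C(SCc2ccccc2)N1` gives 3.6%, and compound 3 `CC1=C(C(=O)Nc2ccc([N+](=O)[O-])cc2)C(c2cccc([N+](=O)[O-])c2)N=C(SCc2ccccc2)N1` gives 4.1%. Compound 3 therefore sits among three numbers that all lie within the usual scatter of one another: its nearest neighbour is compound 2, its furthest compound 1, and neither gap exceeds the scatter. Among the measured compounds shown here, the one recorded step, a number 0.5 percentage points higher from compound 2 to compound 3 (within the scatter), changes the group on the saturated ring carbon and is itself within the scatter.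

Compound 4 `CC1=C(C(=O)Nc2ccc([N+](=O)[O-])cc2)C(c2cccc([N+](=O)[O-])c2)N=C(SCc2ccc(F)cc2)N1` differs from compound 3 by fluoro in place of hydrogen on an aromatic carbon. For the measured compounds named here, no measured step tests this change alone; compound 1 carries the 4-fluorobenzyl group but differs from the others in several further places, so its number cannot be read as a guide. Going by the values given here, since every step so far stayed within the scatter, the step from compound 3 to compound 4 is expected to be a number 0.4 percentage points higher from compound 3 to compound 4 (within the scatter). Compound 4 is estimated at 4.5%, in the range from 0% to 12%.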

Compound 4, a percentage reported as inhibition, in the whole organism at one dose (the size of the read-out at that dose, not a potency): 4.1%
Estimate against measurement, compound 4: 0.4 percentage points above; low and high end bracket the measured number.
By their numbers in this assay, from the lowest: compounds 2, 3, 4 and 1 (each within the scatter of the next).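

In this assay, the change from hydrogen to fluoro on an aromatic carbon para to a large group gives no change at the digits printed from compound 3 to compound 4 (within the scatter) and is here read on its own, with everything else in the molecule held the same. At this position, the change from benzyl to 4-fluorobenzyl therefore yields two compounds that this measurement cannot tell apart, a finding that compound 1, with its several further differences, could not provide. The data on hand offer no explanation for this result.

Going by these compounds, whether an amine, a carboxylic acid or a methoxy group at the same place would separate from hydrogen or fluoro remains open, as does the effect of a longer chain in place of the benzyl arm. This single pair also leaves open whether fluoro would read the same with other groups elsewhere on the shared core.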